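The source may hold more compounds than are shown below. What is called first, only, known or untested is meant among the compounds shown, and "the series" means these compounds.

Measured compounds:
- compound 1, `COc1cc2ncnc(N3CCc4ccccc43)c2cc1NC(=O)/C=C/C(C)C`, gives 6410 nM in a functional assay on A549 cells (Homo sapiens) for antiproliferative activity, read by MTT assay, with a stated time of 72 h; on this read-out higher numbers stand for weaker inhibition and lower numbers for stronger inhibition
- compound 2, `CC(C)/C=C/C(=O)Nc1cc2c(N3CCc4ccccc43)ncnc2cc1O[C@@H]1CCOC1`, gives 8520 nM in this assay

Compound 1 holds the lower of the two numbers, but the step of a 1.3-fold higher number from compound 1 to compound 2 (0.12 log units; within the scatter) lies within the scatter, so the two compounds cannot be told apart on this read-out. That single measured step concerns oxolan-3-yl in place of methyl on an oxygen on an aromatic ring, a position untouched by the change now in question.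

Compound 3, `COc1cc2ncnc(N3CCc4ccccc43)c2cc1NC(=O)/C=C/CN1CCN(C)CC1`, differs from compound 1 by (4-methylpiperazin-1-yl)methyl in place of isopropyl on a double-bonded chain carbon bound to a double-bonded chain carbon. For the measured compounds named here, no measured pair speaks to this part of the molecule, and the one step recorded, from compound 1 to compound 2, sits at a different place and was itself within the scatter. There is therefore no basis for expecting a step beyond the scatter in this assay in either direction, only wide uncertainty. Compound 3 is expected to give about 5500 nM, within a range from 1500 nM to 20000 nM. The step this estimate implies, a 1.2-fold lower number from compound 1 to compound 3 (0.07 log units; within the scatter), is expected to stay within the scatter.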

Compound 3, half-maximal inhibitory concentration: 5360 nM
Compound 3: the middle estimate sits 1.0-fold (0.01 log units) above what was measured, and the stated range covers the measured number.
By their numbers in this assay, from the lowest: compounds 3, 1 and 2 (each within the scatter of the next).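

In this assay the exchange of isopropyl for (4-methylpiperazin-1-yl)methyl, on a double-bonded chain carbon bound to a double-bonded chain carbon, gives a 1.2-fold lower number from compound 1 to compound 3 (0.08 log units; within the scatter) and so leaves the two compounds indistinguishable on this read-out. For the compounds shown here, this is the first measured step at this position, since the step recorded earlier lay elsewhere on the molecule, and it shows that a group with no ring can give way here to one carrying a six-membered non-aromatic ring with 2 hetero atoms without a step beyond the scatter. No supporting measurement is available that bears on this result.

Going by these compounds, it remains open whether another group at this place, such as a dimethylamino group, a carboxylic acid or a longer chain, would move the number beyond the scatter in either direction. Also open, on these data alone, is whether the (4-methylpiperazin-1-yl)methyl group would give a similar result on the core of compound 2, which carries oxolan-3-yl in place of methyl on the oxygen on the aromatic ring.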